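Ring Swap on the Thiocarbonyl: Thiomorpholine to Piperidine

The source may hold more compounds than are shown below. What is called first, only, known or untested is meant among the compounds shown, and "the series" means these compounds.

Measured compounds:
Compound 1 `Cc1cccc(/C(N)=N/NC(=S)N2CCSCC2)n1`: 73.1%
Compound 2 `N/C(=N\NC(=S)N1CCSCC1)c1ccccn1`: 86%

Both compounds were tested in a functional assay on A-375 cells (Homo sapiens) for cytotoxicity, read by MTT assay, with a stated time of 72 h, tested at 30 uM; on this read-out higher numbers stand for more inhibition of growth at the one concentration tested and lower numbers for less inhibition of growth. Compound 1 gives 73.1% and stands lowest of the two numbers; its nearest neighbour is compound 2, which gives 86%, and the step of a number 12.9 percentage points higher from compound 1 to compound 2 (beyond the scatter) lies beyond the scatter. Going by the values given here, that step arises from hydrogen in place of methyl on an aromatic carbon and is the only measured step in the set.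

The unmeasured compound 3 `Cc1cccc(/C(N)=N/NC(=S)N2CCCCC2)n1` differs from compound 1 at another place: piperidin-1-yl in place of thiomorpholin-4-yl on a thiocarbonyl carbon. Among the compounds with values here, no measured step touches the thiocarbonyl carbon or the ring attached to it, so the data give no indication of how such a change moves the read-out. The step of a number 12.9 percentage points higher from compound 1 to compound 2 (beyond the scatter) alters a different part of the molecule and does not bear on this change. Compound 3 is therefore expected to change little, the expected step being a number 3.1 percentage points lower from compound 1 to compound 3 (within the scatter), not beyond the scatter. The estimate for compound 3 is 70%, with a range from 50% to 88%.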

Compound 3, percent growth inhibition at one concentration: 80.9%
Compound 3: the middle estimate sits 10.9 percentage points below what was measured; the measured number falls inside the stated range.
By their numbers in this assay, from the lowest: compounds 1, 3 and 2 (each within the scatter of the next, the first and the last beyond it).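

In this assay, going by these compounds alone, the exchange of thiomorpholin-4-yl for piperidin-1-yl on the thiocarbonyl carbon gives the first reading at this position: a number 7.8 percentage points higher from compound 1 to compound 3 (within the scatter). On this read-out, the two six-membered rings cannot be told apart on the core of compound 1, so the sulfur of thiomorpholin-4-yl is not shown to be required for growth inhibition at the one concentration tested. The data offer no explanation of how either ring acts on the cells.

Compound 2 and compound 3 differ in two places, so their values cannot show whether the ring exchange would read the same on the core without the methyl group. Going by these compounds, it also remains open how the read-out would respond to other groups on the thiocarbonyl carbon, such as morpholin-4-yl, with oxygen in the place of the ring sulfur, or an open-chain dimethylamino group, which would show whether a closed ring matters at this position.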